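The source may report more compounds than this note shows. Statements on the series, on what has been measured and on what is new or still open speak of the compounds shown alone.

Measured compounds:
- compound 1, `Oc1cccc(-c2cc(-c3ccccc3)cc(-c3ccsc3)n2)c1`: 12100 nM
- compound 2, `Oc1cccc(-c2cc(-c3ccccc3)cc(-c3ccco3)n2)c1`: 13700 nM
- compound 3, `Oc1cccc(-c2cc(-c3ccccc3)nc(-c3ccsc3)c2)c1`: 19000 nM

All three were read in a functional assay on MDA-MB-231 cells (Homo sapiens) for cytotoxicity, read by ELISA, with a stated time of 2 days; a higher number here means a weaker inhibitor, a lower number a stronger inhibitor. Within the core of compound 1, the one change recorded is furan-2-yl in place of thiophen-3-yl on an aromatic carbon, and the step it made is a 1.1-fold higher number from compound 1 to compound 2 (0.05 log units; within the scatter). Compound 3 is built from the same atoms as compound 1, joined differently; the difference between the two cores is not broken down here. Their values, like those of compound 2 and compound 3, lie within the scatter of one another, so no ordering among the three is drawn.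

Compound 4, `Oc1cccc(-c2cc(-c3ccccc3)nc(-c3ccco3)c2)c1`, has not yet been measured. It differs from compound 3 by furan-2-yl in place of thiophen-3-yl on an aromatic carbon. For the measured compounds named here, the place description is the same word for word as the one for the change from compound 1 to compound 2, so this is the same change, now made on the core of compound 3. Going by the values given here, the one earlier instance was within the scatter, and nothing in the three measured compounds points to the core of compound 3 responding differently.

In this assay compound 4 is therefore expected to give 21000 nM, estimated between 10000 nM and 42000 nM. Among the compounds with values here, the expected step is a 1.1-fold higher number from compound 3 to compound 4 (0.04 log units; within the scatter), set beside the only measured instance of the change, because a 1.1-fold higher number from compound 1 to compound 2 (0.05 log units; within the scatter) is the one step of this kind that has been measured.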

Compound 4, half-maximal inhibitory concentration: 20800 nM
Compound 4: middle estimate off by 1.0-fold (0.00 log units), on the high side; the range from low to high includes it.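

In this assay, furan-2-yl in place of thiophen-3-yl on an aromatic carbon gives a 1.1-fold higher number from compound 3 to compound 4 (0.04 log units; within the scatter). Set beside the earlier instance, the change carries from one core to the other with no difference that can be read: the same change on two cores in this assay, a 1.1-fold higher number (0.05 log units; within the scatter) from compound 1 to compound 2 and a 1.1-fold higher number (0.04 log units; within the scatter) from compound 3 to compound 4, 1.0-fold (0.01 log units) apart, within the scatter of two such steps

For the compounds shown here, this rests on only two instances, on cores built from the same atoms joined differently, and since neither step lies beyond the scatter, it shows only that this swap stays within the scatter on these two cores, not that a change with a larger step would carry over in the same way or that the same would hold on a more distant core.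

All the compounds shown keep the 3-hydroxyphenyl and phenyl groups and hold a five-membered aromatic ring with 1 hetero atom at the place of the change, so the effect of changing either of those two groups stays open. Also open, from the compounds shown here alone, is how the value would respond to a group of another kind at that place, such as an amine, a carboxylic acid or a longer chain.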